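The source may report more compounds than this note shows. Statements on the series, on what has been measured and on what is new or still open speak of the compounds shown alone.

Compound 3 `CCOC(=O)c1cc2ccc(OCCCn3cc(CNC(=O)CCCCC4CCSS4)nn3)cc2oc1=O` stands lowest of the three numbers in a functional assay on PC-12 cells (Rattus norvegicus) for cytotoxicity, read by MTT assay, with stated times of 3 h and 2 h, tested at 20 uM (on this read-out higher numbers stand for a stronger effect at the one concentration tested and lower numbers for a weaker effect), where compound 3 gives 42.1%. Compound 1 `O=C(CCCCC1CCSS1)NCc1cn(CCCOc2ccc3ccc(=O)oc3c2)nn1` is nearest, giving 42.2% in this assay, and the step of a number 0.1 percentage points lower from compound 1 to compound 3 (within the scatter) lies within the scatter. Compound 2 `Cc1cc(=O)oc2cc(OCCCn3cc(CNC(=O)CCCCC4CCSS4)nn3)ccc12` gives 74.3%, and the step of a number 32.1 percentage points higher from compound 1 to compound 2 (beyond the scatter) is the only large one seen. Compound 4 `COc1ccc(-c2cc3ccc(OCCCn4cc(CNC(=O)CCCCC5CCSS5)nn4)cc3oc2=O)cc1` differs from compound 3 by 4-methoxyphenyl in place of ethoxycarbonyl on an aromatic carbon. For the measured compounds named here, no measured step bears directly on a 4-methoxyphenyl group; the steps at this aromatic carbon show that ethoxycarbonyl left the number where hydrogen had it, while methyl raised it strongly. The expected step is therefore uncertain and is estimated as a number 9.9 percentage points higher from compound 3 to compound 4 (within the scatter). Compound 4 is expected to give 52%, between 30% and 74%.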

Compound 4, a percentage reported as activity, at one concentration (the size of the read-out at that concentration, not a potency): 62%
Estimate against measurement, compound 4: 10 percentage points below; the measured number falls inside the stated range.
By their numbers in this assay, from the lowest: compounds 3 and 1 (each within the scatter of the next); then compound 4; then compound 2.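

In this assay this aromatic carbon, two atoms from the ring oxygen, now proves able to move the number: the change is a number 19.9 percentage points higher from compound 3 to compound 4 (beyond the scatter) for 4-methoxyphenyl in place of ethoxycarbonyl and a number 19.8 percentage points higher from compound 1 to compound 4 (beyond the scatter) for 4-methoxyphenyl in place of hydrogen. Ethoxycarbonyl had left the number where hydrogen had it, so a group at this carbon does not raise it merely by being there. No measurement given here explains the rise. From the compounds shown here alone, whether phenyl without the methoxy group would give the same rise stays open. So does the outcome with an amine or a carboxylic acid at this carbon.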